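Swapping Propyl for Cyclohexyl on Compound 1

A few compounds are considered here, and "the series" means these few. Any claim that something is new, unique, unknown or untested is made for them only; others in the source may bear on it.

In an ADME assay on a cell-free system (plasma, Homo sapiens) for metabolic stability, with a stated time of 90 min (on this read-out lower numbers stand for a less stable compound and higher numbers for a more stable compound), compound 1 `CCCC(=O)OCCCCCC(=O)N[C@H](C(=O)N1C[C@H](O)C[C@H]1C(=O)NCc1ccc(-c2scnc2C)cc1)C(C)(C)C` gives 13%, the lowest of the three numbers measured. Compound 2 `CCCC(=O)NCCCCCC(=O)N[C@H](C(=O)N1C[C@H](O)C[C@H]1C(=O)NCc1ccc(-c2scnc2C)cc1)C(C)(C)C` gives 83%, and compound 3 `Cc1ncsc1-c1ccc(CNC(=O)[C@@H]2C[C@@H](O)CN2C(=O)[C@@H](NC(=O)CCCCCNC(=O)CC(c2ccccc2)c2ccccc2)C(C)(C)C)cc1` gives 149%. Compound 4 `Cc1ncsc1-c1ccc(CNC(=O)[C@@H]2C[C@@H](O)CN2C(=O)[C@@H](NC(=O)CCCCCOC(=O)C2CCCCC2)C(C)(C)C)cc1` has not yet been measured. It differs from compound 1 by cyclohexyl in place of propyl on a carbonyl carbon, with cyclohexyl in place of propyl on a carbonyl carbon. Going by the values given here, only one measured step bears on this, the large and beyond-scatter a number 70 percentage points higher from compound 1 to compound 2 (beyond the scatter). Among the compounds with values here, that step replaces (propylcarbonyl)oxy with (propylcarbonyl)amino, whereas compound 4 carries (cyclohexylcarbonyl)oxy, so no measured step tests this change directly. A modest upward move is therefore expected, an estimated a number 17 percentage points higher from compound 1 to compound 4 (beyond the scatter). For compound 4 the expected value is 30%, within an estimated range of 8% to 65%.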

Compound 4, percent of the compound remaining in the Homo sapiens assay: 14%
Compound 4: the middle estimate sits 16 percentage points above what was measured; low and high end bracket the measured number.
By their numbers in the Homo sapiens assay, from the lowest: compounds 1 and 4 (each within the scatter of the next); then compound 2; then compound 3.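

In the Homo sapiens assay, the larger cyclohexyl on this carbonyl carbon gives no readable change from propyl (a number 1 percentage points higher from compound 1 to compound 4 (within the scatter)). The (cyclohexylcarbonyl)oxy chain also stays far from the (propylcarbonyl)amino chain (a number 69 percentage points lower from compound 2 to compound 4 (beyond the scatter)), so the group on the carbonyl carbon has not closed that gap. In a physicochemical assay for lipophilicity, read by LC-MS, using the shake flask method, in phosphate buffer, with a stated time of 50 min, at pH 7.4 (on this read-out higher numbers stand for higher lipophilicity and lower numbers for lower lipophilicity), compound 1 gives 0.5 and compound 4 gives 1.1. Higher lipophilicity came without a readable change in percent remaining, as the physicochemical assay shows: the measured distribution coefficient of compound 1, 0.5, and of compound 4, 1.1, a number 0.60 log units higher (beyond the scatter).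

As far as these compounds go, whether cyclohexyl would behave the same way on the (propylcarbonyl)amino chain stays open. So does the effect of an aminomethyl group on this carbonyl carbon.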